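Chloromethyl for trifluoromethylphenyl on the amide carbonyl

The source may hold more compounds than are shown below. What is called first, only, known or untested is meant among the compounds shown, and "the series" means these compounds.

Measured compounds:
- compound 1 `CC(=O)N(/N=N/c1ccc([N+](=O)[O-])cc1Cl)c1ccc([N+](=O)[O-])cc1Cl`: in a functional assay on HeLa cells (Homo sapiens) for cytotoxicity, read by MTT assay, with a stated time of 72 h (on this read-out higher numbers stand for weaker inhibition and lower numbers for stronger inhibition), compound 1 gives 630 nM
- compound 2 `O=C(c1ccccc1C(F)(F)F)N(/N=N/c1ccc([N+](=O)[O-])cc1Cl)c1ccc([N+](=O)[O-])cc1Cl`: in this assay compound 2 gives 10600 nM
- compound 3 `O=C(c1ccc(C(F)(F)F)cc1)N(/N=N/c1ccc([N+](=O)[O-])cc1Cl)c1ccc([N+](=O)[O-])cc1Cl`: in this assay compound 3 gives 1060 nM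

Compound 3 holds the second highest number of the three. Its nearest neighbour is compound 1, a 1.7-fold higher number from compound 1 to compound 3 (0.23 log units; within the scatter), which is within the scatter, so the two cannot be ordered. Its furthest is compound 2, a 10-fold lower number from compound 2 to compound 3 (1.00 log units; beyond the scatter). Compound 2 also stands apart from compound 1, a 17-fold higher number from compound 1 to compound 2 (1.23 log units; beyond the scatter), and so gives the weakest inhibition of the set.

Compound 4 `O=C(CCl)N(/N=N/c1ccc([N+](=O)[O-])cc1Cl)c1ccc([N+](=O)[O-])cc1Cl` differs from compound 3 in one place: chloromethyl in place of 4-(trifluoromethyl)phenyl on a carbonyl carbon. Within the data shown here, no measured step swaps a group of this kind. What bears on it is the acyl variation already seen: the small methyl of compound 1 and the 4-(trifluoromethyl)phenyl of compound 3 sit within the scatter of each other, while the 2-(trifluoromethyl)phenyl of compound 2 stands apart. A return to a small group on the carbonyl carbon is therefore expected to leave the number near those of compound 1 and compound 3. For compound 4 in this assay the step of a 1.8-fold lower number from compound 3 to compound 4 (0.25 log units; within the scatter) is expected, within the scatter. Compound 4 is estimated at 600 nM, between 200 nM and 1800 nM.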

Compound 4, half-maximal inhibitory concentration: 550 nM
The estimate for compound 4 lay 1.1-fold (0.04 log units) above the measured number; low and high end bracket the measured number.
By their numbers in this assay, from the lowest: compounds 4, 1 and 3 (each within the scatter of the next); then compound 2.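

Working notes: in this assay, adding chloro to the methyl on the carbonyl carbon gives no resolvable change (a 1.1-fold lower number from compound 1 to compound 4 (0.06 log units; within the scatter)), and chloromethyl and 4-(trifluoromethyl)phenyl cannot be ordered either (a 1.9-fold lower number from compound 3 to compound 4 (0.28 log units; within the scatter)). Compound 2 remains apart from this group, now also against chloromethyl (a 19-fold lower number from compound 2 to compound 4 (1.28 log units; beyond the scatter)), so among the four acyl groups only 2-(trifluoromethyl)phenyl separates from the others. No measurement available here offers a cause for these steps.

From the compounds shown here alone, whether an aminomethyl group or a longer chain ending in chlorine on the carbonyl carbon would stay with compound 1, compound 3 and compound 4 remains open. Also open, going by these compounds, is whether 2-methylphenyl or 2-chlorophenyl would give a number like that of compound 2, or whether that number is particular to 2-(trifluoromethyl)phenyl.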